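Swapping ethyl for tert-butyl: what growth inhibition to expect

The compounds below may be only part of what the source reports. "The series", "measured", "known", "first", "only" and "open" are said of these compounds alone.

Compound 1 `CCc1ccc(SCc2ccc(/C=C/C(=O)Nc3ccccc3N)cc2)cc1` gives 13.2%
Compound 2 `CCc1ccc(SCc2ccc(C(=O)Nc3ccccc3N)cc2)cc1` gives 25.7%
Compound 3 `Nc1ccccc1NC(=O)/C=C/c1ccc(CSc2ccc(C(F)(F)F)cn2)cc1` gives 12.1%

In a functional assay on SMMC-7721 cells (Homo sapiens) for inhibition, read by CCK-8 assay, with a stated time of 72 h, tested at 2 uM (a higher number here means more inhibition of growth at the concentration tested, a lower number less inhibition of growth), compound 2 gives 25.7%, the highest of the three numbers. Compound 1 at 13.2% and compound 3 at 12.1% both sit lower than compound 2, beyond the usual scatter.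

Compound 4 `CC(C)(C)c1ccc(SCc2ccc(C(=O)Nc3ccccc3N)cc2)cc1` differs from compound 2 in one place: tert-butyl in place of ethyl on an aromatic carbon. In short, tert-butyl stands in place of ethyl on an aromatic carbon.

For the measured compounds named here, only one measured step bears on this part of the molecule: a number 1.1 percentage points lower from compound 1 to compound 3 (within the scatter). There, 5-(trifluoromethyl)pyridin-2-yl replaces 4-ethylphenyl on a sulfur. Going by the values given here, that is a different and larger swap, so it is only a loose guide, and no measured step tests tert-butyl directly. Even so, that swap barely moved the number, so no clear shift in either direction is expected in this assay. The estimated change is a number 0.7 percentage points lower from compound 2 to compound 4 (within the scatter), which is expected to stay within the scatter. The expected value for compound 4 is 25%, with an estimated range from 13% to 38%.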

Compound 4, percent growth inhibition at one concentration: 23.6%
Beside the measured number, compound 4's estimate is 1.4 percentage points above it, and the stated range covers the measured number.
By their numbers in this assay, from the lowest: compounds 3 and 1 (each within the scatter of the next); then compounds 4 and 2 (each within the scatter of the next).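

For the compounds shown here, the swap is the first direct test of the group on this aromatic carbon, para to a large group: in this assay, tert-butyl in place of ethyl gives a number 2.1 percentage points lower from compound 2 to compound 4 (within the scatter). Going from 2 heavy atoms to 4 heavy atoms, all carbon, therefore leaves compound 2 and compound 4 indistinguishable in this read-out, which the earlier step, a much larger swap made on the core of compound 1, could not show. Nothing available here explains this outcome.

Going by these compounds, whether a carboxylic acid, an amine or a methoxy group at this place would give a similar number remains open. So does whether tert-butyl in place of ethyl would give a similar result on the core of compound 1.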